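Piperazine chain lengthening in a benzimidazolone urea series

The source may report more compounds than this note shows. Statements on the series, on what has been measured and on what is new or still open speak of the compounds shown alone.

A small set of benzimidazolone ureas was examined in an assay on isolated protein (striatum) for binding affinity to 5-hydroxytryptamine receptor 4 (Cavia porcellus), read by radioligand binding; on this read-out lower numbers stand for stronger inhibition and higher numbers for weaker inhibition. Compound 1 `CCCN1CCN(CCNC(=O)n2c(=O)n(C3CC3)c3ccccc32)CC1` gives 8.2 nM in this assay. Compound 2 `CC(C)n1c(=O)n(C(=O)NCCN2CCN(C)CC2)c2ccccc21` gives 91.1 nM, and compound 3 `CCN1CCN(CCNC(=O)n2c(=O)n(C(C)C)c3ccccc32)CC1` gives 104 nM. Compound 1 stands lowest of the three, and its gaps to compound 2 and compound 3 are both beyond the usual scatter. The difference between the core of compound 1 and the core of compound 2 is not broken down here.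

Compounds 2 and 3 differ in one place, (methyl in place of hydrogen on a saturated chain carbon bound to an amine nitrogen in a ring), and this gave a 1.1-fold higher number from compound 2 to compound 3 (0.06 log units; within the scatter), a step within the scatter.

Compound 4 `CCCCN1CCN(CCNC(=O)n2c(=O)n(C3CC3)c3ccccc32)CC1` has not been measured in this assay. It differs from compound 1 by methyl in place of hydrogen on a saturated chain carbon, three bonds along the chain from an amine nitrogen in a ring. Within the data shown here, this is the same kind of change as the one from compound 2 to compound 3, though not the same: there the added carbon sat on a saturated chain carbon bound to an amine nitrogen in a ring, whereas here it sits three bonds along the chain from that nitrogen.

For compound 4 the expected step is a 1.2-fold higher number from compound 1 to compound 4 (0.09 log units; within the scatter). This expectation rests on the earlier step of a 1.1-fold higher number from compound 2 to compound 3 (0.06 log units; within the scatter), which was within the scatter, and on the single chain carbon added each time. Compound 4 is therefore estimated at 10 nM, most likely between 4 nM and 25 nM.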

Compound 4, inhibition constant: 13.3 nM
Beside the measured number, compound 4's estimate is 1.3-fold (0.12 log units) below it, and the stated range covers the measured number.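

In this assay, lengthening propyl to butyl on the core of compound 1 gave a small step (a 1.6-fold higher number from compound 1 to compound 4 (0.21 log units; within the scatter)), and it can be set beside the earlier step on the other core: the same change on two cores in this assay, a 1.1-fold higher number (0.06 log units; within the scatter) from compound 2 to compound 3 and a 1.6-fold higher number (0.21 log units; within the scatter) from compound 1 to compound 4, 1.4-fold (0.15 log units) apart, within the scatter of two such steps. Across these two pairs, then, one added chain carbon left the number within the scatter on both cores, and the two steps cannot be told apart, so the change carried over from one core to the other without any visible difference. Among these compounds, this does not show that the change is without effect or that it would behave the same way on any further core, since the evidence is only two pairs, each step is small enough to be lost in the scatter, and the added carbon sits at a different place along the chain in each pair.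

The compounds shown leave open how a longer chain than butyl, or a chain ending in a hydroxyl group or a carboxylic acid, would read on the same amine nitrogen. They also leave open how much the core alone contributes, as no pair shown differs only there.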